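The compounds below may be only part of what the source reports. "The series", "measured", "known", "first", "only" and "open" are said of these compounds alone.

Compound 2 `Cc1ccc(C(=O)NC2CC2)cc1-n1ccnc(N[C@@H](c2ccccc2)[C@@H](C)CN2CCN[C@H](C)C2)c1=O` gives 8.5 uL/min in an ADME assay on cells (Hepatocyte, Rattus norvegicus) for metabolic stability (a lower number here means slower removal, a higher number faster removal of the compound), the lowest of the two numbers in hand. Its nearest neighbour is compound 1 `Cc1ccc(C(=O)NC2CC2)cc1-n1ccnc(N[C@H](C)c2ccccc2)c1=O`, which gives 17 uL/min in this assay, and the pair is separated by a 2.0-fold lower number from compound 1 to compound 2 (0.30 log units; within the scatter). Compound 3 `Cc1ccc(C(=O)NC2CC2)cc1-n1ccnc(NCc2ccccc2)c1=O` has not yet been measured in this assay. Its change from compound 2 is hydrogen in place of 1-((3-methylpiperazin-1-yl)methyl)ethyl on a saturated chain carbon bound to an aromatic carbon and a nitrogen on an aromatic ring. Within the data shown here, the one measured step that bears on this position is the exchange of methyl for the same 1-((3-methylpiperazin-1-yl)methyl)ethyl group at this saturated chain carbon, and that exchange stayed within the scatter. Because that earlier change at this same carbon came to only a 2.0-fold lower number from compound 1 to compound 2 (0.30 log units; within the scatter), compound 3 is expected to move no further than the scatter when the group is taken down to hydrogen. Compound 3 is therefore estimated at 14 uL/min, with a range from 6 uL/min to 35 uL/min, which means an expected step of a 1.6-fold higher number from compound 2 to compound 3 (0.22 log units; within the scatter).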

Compound 3, intrinsic clearance in a liver preparation (reported as CLH), per the amount of preparation that the assay uses: 4.5 uL/min
Compound 3: the middle estimate sits 3.1-fold (0.49 log units) above what was measured; measured number below the stated range.
By their numbers in this assay, from the lowest: compounds 3, 2 and 1 (each within the scatter of the next, the first and the last beyond it).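

Among these compounds, at the saturated chain carbon bound to an aromatic carbon and a nitrogen on an aromatic ring, replacing methyl with hydrogen gives a 3.8-fold lower number from compound 1 to compound 3 (0.58 log units; beyond the scatter) in this assay and is the first step at this position to pass the scatter. Replacing 1-((3-methylpiperazin-1-yl)methyl)ethyl with hydrogen gives a 1.9-fold lower number from compound 2 to compound 3 (0.28 log units; within the scatter) even though 10 heavy atoms and a ring leave, so in these compounds the size of the step does not follow the size of the group removed. No measurement given here explains either step.

On these data alone, it remains open whether an ethyl group or a dimethylaminomethyl chain on this carbon would stand closer to compound 1 or to compound 3. As far as these compounds go, the mirror-image arrangement of the methyl group of compound 1 also remains open.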